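Swapping Fluorines for Chlorines on the Sulfonyl Ring

A few compounds are considered here, and "the series" means these few. Any claim that something is new, unique, unknown or untested is made for them only; others in the source may bear on it.

Of the compounds shown here, three that share one core have been measured in an ADME assay on microsomes from liver (Homo sapiens) for metabolic stability, tested at 2.5 uM; on this read-out lower numbers stand for slow clearance and higher numbers for fast clearance. Compound 1 `COc1ccc(-c2c(S(=O)(=O)c3cc(F)cc(F)c3)cnc3c(F)cccc23)cc1` gives 2.59 mL/min. Compound 2 `O=S(=O)(c1cc(F)cc(F)c1)c1cnc2c(F)cccc2c1-c1ccc(Cl)cc1` gives 0.73 mL/min, and compound 3 `O=S(=O)(c1cc(F)cc(F)c1)c1cnc2c(F)cccc2c1-c1cccc(F)c1` gives 1.18 mL/min. Compound 2 stands at the low end of these three numbers: the step from compound 1 is a 3.5-fold lower number from compound 1 to compound 2 (0.55 log units; beyond the scatter), while the step onward is a 1.6-fold higher number from compound 2 to compound 3 (0.21 log units; within the scatter), so compound 2 and compound 3 cannot be told apart on this read-out. The remaining step is a 2.2-fold lower number from compound 1 to compound 3 (0.34 log units; beyond the scatter).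

Compound 4 `O=S(=O)(c1cc(Cl)cc(Cl)c1)c1cnc2c(F)cccc2c1-c1ccc(Cl)cc1` differs from compound 2 in one place: 3,5-dichlorophenyl in place of 3,5-difluorophenyl on a sulfonyl sulfur. Within the data shown here, none of the measured steps touches the ring on the sulfonyl sulfur; all three concern the aromatic ring that carries the methoxy, chloro or fluoro group in compound 1, compound 2 and compound 3. The step of a 3.5-fold lower number from compound 1 to compound 2 (0.55 log units; beyond the scatter) shows that a chloro group on that other ring goes together with a low number, but it says nothing about exchanging fluorine for chlorine on the sulfonyl ring. Among the measured compounds shown here, with no step bearing directly on the change, no shift beyond the scatter is expected, and compound 4 is estimated at 0.9 mL/min, within a range from 0.4 mL/min to 2 mL/min. The expected step is therefore a 1.2-fold higher number from compound 2 to compound 4 (0.09 log units; within the scatter).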

Compound 4, intrinsic clearance in a liver preparation (reported as CLH), per the amount of preparation that the assay uses: 0.78 mL/min
Estimate against measurement, compound 4: 1.2-fold (0.06 log units) above, within the range that was stated.
By their numbers in this assay, from the lowest: compounds 2, 4 and 3 (each within the scatter of the next); then compound 1.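

Among these compounds, this is the first change at the group on the sulfonyl sulfur: in this assay, 3,5-dichlorophenyl in place of 3,5-difluorophenyl gives a 1.1-fold higher number from compound 2 to compound 4 (0.03 log units; within the scatter) and so leaves the two compounds indistinguishable on this read-out. The earlier steps shown here all concerned the other aromatic ring, whereas this one shows that, with a 4-chlorophenyl group on that ring, exchanging both fluorines on the sulfonyl ring for chlorines produces no change that can be told apart from the scatter of repeated measurements. No accompanying measurement offers an explanation for this flat result.

This single pair cannot show whether the same exchange would also make so little difference alongside the 4-methoxyphenyl group of compound 1, which has the highest number of the set, or the 3-fluorophenyl group of compound 3. As far as these compounds go, it also remains open how the read-out would respond to a more different group on the sulfonyl sulfur, such as a phenyl ring carrying an amine or a carboxylic acid, or a longer chain in place of the ring.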